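A few compounds are considered here, and "the series" means these few. Any claim that something is new, unique, unknown or untested is made for them only; others in the source may bear on it.

Measured so far:
- compound 1 `COc1ccc(-c2cc3nccc(-c4cc(OC)c(OC)c(OC)c4)n3n2)cc1N` — 138 nM
- compound 2 `COc1cc(-c2ccnc3cc(-c4ccc(C(C)(C)C)cc4)nn23)cc(OC)c1OC` — > 10000 nM
- compound 3 `COc1cc(-c2ccnc3cc(-c4c[nH]c5ccccc45)nn23)cc(OC)c1OC` — 29 nM

In a functional assay on A549 cells (Homo sapiens) for inhibition, read by CCK-8 assay, with a stated time of 48 h (a lower number here means a stronger inhibitor, a higher number a weaker inhibitor), compound 3 gives 29 nM, the lowest of the two numbers; compound 1 stands nearest, a 4.8-fold lower number from compound 1 to compound 3 (0.68 log units; beyond the scatter). For compound 2 the assay reports only a limit, (the limit of > 10000 nM in this assay, at which 1 of the 3 values shown sits), not a number. The steps bearing on the variable position are an at least 72-fold higher number from compound 1 to compound 2 (1.86 log units; beyond the scatter) and an at least 340-fold lower number from compound 2 to compound 3 (2.53 log units; beyond the scatter), both large.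

Compound 4 `COc1ccc(-c2cc3nccc(-c4cc(OC)c(OC)c(OC)c4)n3n2)cc1` is not yet measured. It differs from compound 3 in one place: 4-methoxyphenyl in place of 1H-indol-3-yl on an aromatic carbon. The relevant comparisons are the step away from the 1H-indol-3-yl group, an at least 340-fold lower number from compound 2 to compound 3 (2.53 log units; beyond the scatter) read in reverse, and the step from 3-amino-4-methoxyphenyl to 4-(tert-butyl)phenyl, an at least 72-fold higher number from compound 1 to compound 2 (1.86 log units; beyond the scatter). Compound 4 carries the 4-methoxyphenyl group, which shares the methoxy of compound 1 but lacks its amino group, and is unlike the 4-(tert-butyl)phenyl of compound 2. A step to a higher number is therefore expected in this assay, beyond the scatter, a 14-fold higher number from compound 3 to compound 4 (1.14 log units; beyond the scatter), most likely landing near or somewhat weaker than compound 1 rather than at the limit seen for compound 2. Compound 4 is estimated at 400 nM, within 100 nM to 3000 nM.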

Compound 4, half-maximal inhibitory concentration: 376 nM
Compound 4: middle estimate off by 1.1-fold (0.03 log units), on the high side, within the range that was stated.
By their numbers in this assay, from the lowest: compound 3; then compound 1; then compound 4. At a limit, above all of these: compound 2.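

In this assay, removing the amino group from the aryl ring costs only a modest step, a 2.7-fold higher number from compound 1 to compound 4 (0.44 log units; beyond the scatter), so the amino group of compound 1 helps but is not required for a nanomolar reading at this position. Compound 2 stands at a limit, and the step from it, an at least 26-fold lower number from compound 2 to compound 4 (1.42 log units; beyond the scatter), comes from methoxy in place of tert-butyl alone, which ties the loss seen with compound 2 to the tert-butyl group and not to the missing amino group. The largest gain among the measured numbers belongs to the 1H-indol-3-yl group, as a 13-fold higher number from compound 3 to compound 4 (1.11 log units; beyond the scatter) shows, and this makes compound 3 the strongest of the four compounds shown.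

The step between compound 3 and compound 4 changes the ring system, the hydrogen-bond donor and the hydrogen-bond acceptor together, so the compounds shown cannot say which of these carries the gain; a 1-methylindol-3-yl group would test the indole hydrogen directly. On these data alone, the role of the methoxy on the phenyl ring also stays open, since no smaller or differently built group, such as a fluorine or a hydroxyl, appears in its place.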